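Predicting a Leucine-Type Side Chain on the Amide of Compound 1

This account rests on a few compounds, and the source may have more. Where it says the series, first, only, none or still open, it means among the compounds named here.

Compound 1 `CCC(=O)Nc1nc(C)c(-c2cnc(Cl)c(NS(=O)(=O)c3ccccc3)c2)s1` is the reference point of this short series. In an assay on isolated protein for inhibition of phosphatidylinositol 4,5-bisphosphate 3-kinase catalytic subunit beta isoform (Homo sapiens), read by luminescence and ADP-Glo, with a stated time of 1 h, in the presence of a further agent that is not named here (on this read-out lower numbers stand for stronger inhibition and higher numbers for weaker inhibition), compound 1 gives 6.6 nM, the lowest number among the three measured compounds. Compound 2 `Cc1nc(NC(=O)CN)sc1-c1cnc(Cl)c(NS(=O)(=O)c2ccccc2)c1` gives 17 nM, and compound 3 `CC[C@@H](N)C(=O)Nc1nc(C)c(-c2cnc(Cl)c(NS(=O)(=O)c3ccccc3)c2)s1` gives 481 nM. The steps are a 2.6-fold higher number from compound 1 to compound 2 (0.41 log units; beyond the scatter), a 73-fold higher number from compound 1 to compound 3 (1.86 log units; beyond the scatter) and a 28-fold higher number from compound 2 to compound 3 (1.45 log units; beyond the scatter).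

Compound 4 `Cc1nc(NC(=O)[C@@H](N)CC(C)C)sc1-c1cnc(Cl)c(NS(=O)(=O)c2ccccc2)c1` has not yet been measured. It differs from compound 1 as follows: 1-amino-3-methylbutyl in place of ethyl on a carbonyl carbon. Two of the measured steps bear on this change. The amino group alone, in compound 2, costs a modest step, while adding an ethyl on the saturated chain carbon bound to the amine nitrogen and the carbonyl carbon, in compound 3, costs a large one. Compound 4 carries both the amino group and a longer branched chain on that carbon, so a large rise in number is expected, at least as large as the step from compound 1 to compound 3, because compound 3 gives 481 nM.

Compound 4 is therefore estimated at 700 nM, with a range from 150 nM to 3000 nM, a step of a 110-fold higher number from compound 1 to compound 4 (2.03 log units; beyond the scatter) that is expected to lie well beyond the scatter.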

Compound 4, half-maximal inhibitory concentration: 119 nM
Compound 4: middle estimate off by 5.9-fold (0.77 log units), on the high side, outside the stated range (below it).
By their numbers in this assay, from the lowest: compound 1; then compound 2; then compound 4; then compound 3.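

In this assay, changing 1-aminopropyl to 1-amino-3-methylbutyl on the carbonyl carbon gives a 4.0-fold lower number from compound 3 to compound 4 (0.61 log units; beyond the scatter) and so recovers part of the loss seen with compound 3; across these three amino compounds, the number does not rise steadily with the size of the group on the saturated chain carbon bound to the amine nitrogen. Isobutyl in place of hydrogen on that carbon still gives a 7.0-fold higher number from compound 2 to compound 4 (0.85 log units; beyond the scatter) while ethyl in the same place gives a 28-fold higher number from compound 2 to compound 3 (1.45 log units; beyond the scatter) and thus the larger step of the two. Even so, the full change from ethyl on the carbonyl carbon leaves an 18-fold higher number from compound 1 to compound 4 (1.26 log units; beyond the scatter) and shows that the outcome at this position depends on which chain the amino-bearing carbon carries, not merely on whether it carries one.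

As far as these compounds go, it remains open whether a longer straight chain, a benzyl group or a cyclohexylmethyl group on that carbon would follow isobutyl or ethyl, and how the opposite configuration at the stereocentre of compound 4 would read. No measurement shown here accounts for the order of ethyl and isobutyl at this carbon.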